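Toward the benzothiazolyl amine: a cytotoxicity outlook

The source may hold more compounds than are shown below. What is called first, only, known or untested is meant among the compounds shown, and "the series" means these compounds.

Three compounds built on the shared core carry different groups on the ring nitrogen. Compound 1 `Cc1nc(NC(=O)NC2CCCCC2)c(C)c(C(OC(C)(C)C)C(=O)O)c1-c1ccc2c(c1)CCCO2` gives 17000 nM in an ADME assay on MT4 cells (Homo sapiens) for cytotoxicity, read by MTT assay; on this read-out lower numbers stand for higher toxicity in this test and higher numbers for lower toxicity in this test. Compound 2 `Cc1ccc(-c2c(C)nc(NC(=O)NC3CCOCC3)c(C)c2C(OC(C)(C)C)C(=O)O)cc1C` gives 29000 nM in this assay, and compound 3 `Cc1ccc(-c2c(C)nc(NS(=O)(=O)c3cccc4ccccc34)c(C)c2C(OC(C)(C)C)C(=O)O)cc1C` gives 16000 nM. The three numbers lie within the scatter of one another, so compound 2 stands apart from neither of its neighbours.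

The unmeasured compound 4 `Cc1ccc(-c2c(C)nc(Nc3nc4ccccc4s3)c(C)c2C(OC(C)(C)C)C(=O)O)cc1C` differs from compound 2 by 1,3-benzothiazol-2-yl in place of (oxan-4-yl)carbamoyl on a nitrogen on an aromatic ring. Among the compounds with values here, no step between measured compounds matches this change, so its size cannot be read off directly. Compound 3, which also replaces the urea with an aromatic system on that nitrogen, gives 16000 nM, a number within the scatter of compound 2. The expectation is therefore a step from compound 2 to compound 4 of a 1.9-fold lower number from compound 2 to compound 4 (0.29 log units; within the scatter), which would not exceed the scatter. Compound 4 is estimated at 15000 nM in this assay, with a range from 6000 nM to 40000 nM.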

Compound 4, half-maximal cytotoxic concentration: 6600 nM
Estimate against measurement, compound 4: 2.3-fold (0.36 log units) above; the range from low to high includes it.
By their numbers in this assay, from the lowest: compound 4; then compounds 3, 1 and 2 (each within the scatter of the next).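

In this assay, within the data shown here, the position on the ring nitrogen turns out not to be indifferent: a 4.4-fold lower number from compound 2 to compound 4 (0.64 log units; beyond the scatter) is a step beyond the scatter, whereas the earlier compounds lay within the scatter of one another and offered no single change to read. The step comes from a swap in which the heavy-atom count stays the same, while a non-aromatic ring and a hydrogen-bond donor leave and two aromatic rings and a sulfur enter, so size alone in that sense does not set the number. Nothing measured here accounts for the step.

As far as these compounds go, whether the lower number follows the sulfur, the five-membered aromatic ring or the fused benzene ring stays open; a benzoxazol-2-yl or a plain phenyl on that nitrogen would separate these. Also open, from the compounds shown here alone, is whether the same change carries over to the core of compound 1.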